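The source may hold more compounds than are shown below. What is called first, only, known or untested is meant among the compounds shown, and "the series" means these compounds.

Of the compounds shown here, three built on one shared core have been measured in a functional assay on isolated protein for inhibition of Glucose-dependent insulinotropic receptor (Homo sapiens), read by HTRF and cAMP accumulation; on this read-out lower numbers stand for an effect already at smaller amounts and higher numbers for an effect only at larger amounts of compound. Compound 1 `CCC1(OC(=O)N2CCC(Oc3ncnc(Oc4ccc(S(C)(=O)=O)nc4C)c3F)CC2)CC1` gives 22 nM in this assay. Compound 2 `Cc1nc(S(C)(=O)=O)ccc1Oc1ncnc(OC2CCN(C(=S)OC(C)C)CC2)c1F` gives 69.9 nM, and compound 3 `CCC(F)(F)C(=O)N1CCC(Oc2ncnc(Oc3ccc(S(C)(=O)=O)nc3C)c2F)CC1` gives 17.4 nM. Among these three numbers compound 1 holds the second highest: the step of a 1.3-fold lower number from compound 1 to compound 3 (0.10 log units; within the scatter) stays within the scatter, whereas the step of a 3.2-fold higher number from compound 1 to compound 2 (0.50 log units; beyond the scatter) lies beyond it, as does the step of a 4.0-fold lower number from compound 2 to compound 3 (0.60 log units; beyond the scatter).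

Compound 4 `Cc1nc(S(C)(=O)=O)ccc1Oc1ncnc(OC2CCN(C(=O)c3noc(C(C)(C)F)n3)CC2)c1F` has not yet been measured in this assay. It differs from compound 1 in one place: a group of 9 heavy atoms (5 carbon, 2 nitrogen, 1 oxygen, 1 fluorine; one five-membered aromatic ring with 3 hetero atoms) in place of a group of 6 heavy atoms (5 carbon, 1 oxygen; one three-membered non-aromatic ring of carbon only), on a carbonyl carbon. The measured step that speaks most directly to this change is the one made at the same carbonyl carbon, a 1.3-fold lower number from compound 1 to compound 3 (0.10 log units; within the scatter), which remained within the scatter. The two other steps, a 3.2-fold higher number from compound 1 to compound 2 (0.50 log units; beyond the scatter) and a 4.0-fold lower number from compound 2 to compound 3 (0.60 log units; beyond the scatter), were made on the amine nitrogen in a ring, a different place, and so bear less on this exchange. Among the compounds with values here, because the one comparable exchange at the carbonyl carbon gave only a 1.3-fold lower number from compound 1 to compound 3 (0.10 log units; within the scatter), a small step of about a 1.1-fold higher number from compound 1 to compound 4 (0.06 log units; within the scatter) is expected here, without a clear direction and likely within the scatter. Compound 4 is therefore estimated at 25 nM in this assay, with a range from 10 nM to 65 nM.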

Compound 4, half-maximal effective concentration: 14 nM
Beside the measured number, compound 4's estimate is 1.8-fold (0.25 log units) above it, and the stated range covers the measured number.
By their numbers in this assay, from the lowest: compounds 4, 3 and 1 (each within the scatter of the next); then compound 2.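

In this assay, within the data shown here, the group on the carbonyl carbon can be changed further than the earlier compounds showed: bringing in the group of 9 heavy atoms, with its five-membered aromatic ring with 3 hetero atoms, gives only a small step (a 1.6-fold lower number from compound 1 to compound 4 (0.20 log units; within the scatter)). Against the fluorine-bearing chain of compound 3 the picture is the same (a 1.2-fold lower number from compound 3 to compound 4 (0.09 log units; within the scatter)), so three quite different groups at this place, one with a three-membered ring, one with no ring and one with an aromatic ring, cannot be told apart on this read-out. Compound 2 remains the one that stands apart, now also by a step beyond the scatter (a 5.0-fold lower number from compound 2 to compound 4 (0.70 log units; beyond the scatter)), and among these four compounds it alone carries sulfur in the group on the amine nitrogen in a ring.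

Nothing available explains why these three groups read alike or why compound 2 differs from them. Going by these compounds, it also remains open whether this tolerance would hold for an amine or a carboxylic acid on the carbonyl carbon, and whether the fluorine of compound 4 matters at all, which a hydrogen or a methyl group in its place could test.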